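Azole swap on the chain carbon: tetrazole after triazole

The source may report more compounds than this note shows. Statements on the series, on what has been measured and on what is new or still open speak of the compounds shown alone.

Compound 2 `Cc1cc(Cl)ccc1-c1cccc(COc2ccc([C@H](CC(=O)O)c3ncnn3C)cc2)c1` stands lowest of the two numbers in an ADME assay on the whole organism for pharmacokinetics, with Rattus norvegicus as the target, at a dose of 2 mg/kg by the oral route (on this read-out higher numbers stand for higher oral bioavailability and lower numbers for lower oral bioavailability), where compound 2 gives 18%; compound 1 `Cc1cc(Cl)ccc1-c1cccc(COc2ccc([C@H](CC(=O)O)c3nccn3C)cc2)c1` gives 48%. Compound 3 `Cc1cc(Cl)ccc1-c1cccc(COc2ccc([C@H](CC(=O)O)c3nnnn3C)cc2)c1` differs from compound 2 by 1-methyl-1H-tetrazol-5-yl in place of 1-methyl-1H-1,2,4-triazol-5-yl on a saturated chain carbon bound to an aromatic carbon and a saturated chain carbon. Going by the values given here, the only measured step bearing on this change is a number 30 percentage points lower from compound 1 to compound 2 (beyond the scatter), a ring exchange of the same kind at the same place, and it ran downward. Among the compounds with values here, no step involving the tetrazole is known. A further modest drop or a change within the scatter is therefore expected for compound 3, as a number 8 percentage points lower from compound 2 to compound 3 (within the scatter). The estimate for compound 3 in this assay is 10%, with a range from 2% to 30%.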

Compound 3, oral bioavailability: 53%
The estimate for compound 3 lay 43 percentage points below the measured number; measured number above the stated range.
By their numbers in this assay, from the lowest: compound 2; then compounds 1 and 3 (each within the scatter of the next).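

In this assay, the ring on this saturated chain carbon does not follow a one-way trend: 1-methyl-1H-tetrazol-5-yl in place of 1-methyl-1H-1,2,4-triazol-5-yl gives a number 35 percentage points higher from compound 2 to compound 3 (beyond the scatter). Set against 1-methyl-1H-imidazol-2-yl, the same group gives a number 5 percentage points higher from compound 1 to compound 3 (within the scatter), so compound 2 stands alone among the three. Exchanging a single ring carbon for nitrogen, with the heavy-atom count unchanged, is enough to move this read-out beyond the scatter.

Nothing available accounts for this reversal. Still open, as far as these compounds go, is whether a 1-ethyl group in place of the 1-methyl group on the tetrazole would keep the number seen for compound 3.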